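The compounds below may be only part of what the source reports. "The series", "measured", "known", "first", "only" and "open" are said of these compounds alone.

Compound 1 `COC(=O)c1ccc(C#CCCCCC(=O)c2ncc(-c3ccccn3)o2)cc1` gives 25 nM in an assay for inhibition of Fatty-acid amide hydrolase 1 (Rattus norvegicus); a higher number here means a weaker inhibitor, a lower number a stronger inhibitor.
Compound 2 `CC(C)(C)OC(=O)Nc1ccc(C#CCCCCC(=O)c2ncc(-c3ccccn3)o2)cc1` gives 23 nM in this assay.
Compound 3 `O=C(CCCCCCc1ccccc1C(=O)O)c1ncc(-c2ccccn2)o1` gives > 600 nM in this assay, which is a limit of the assay.

Compound 3 therefore stands at the limit of > 600 nM in this assay, at which 1 of the 3 values shown sits, the only one of the three without a number. Compound 4 `O=C(CCCCCCc1ccccc1Cl)c1ncc(-c2ccccn2)o1` differs from compound 3 by chloro in place of carboxy on an aromatic carbon. Within the data shown here, the one measured step, a 1.1-fold lower number from compound 1 to compound 2 (0.04 log units; within the scatter), also exchanged one group for another on the outer ring and left the number essentially unchanged, but neither group there was an acid, so no measured step directly covers the present change. Compound 1 and compound 2, which carry no carboxy, both give numbers. Compound 4 is expected to give a number, estimated at 200 nM, between 30 nM and 1500 nM. This would mean an expected step of an at least 3.0-fold lower number from compound 3 to compound 4 (0.47 log units; beyond the scatter).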

Compound 4, inhibition constant: 1.9 nM
Compound 4: the middle estimate sits 110-fold (2.02 log units) above what was measured; measured number below the stated range.
By their numbers in this assay, from the lowest: compound 4; then compounds 2 and 1 (each within the scatter of the next). At a limit, above all of these: compound 3.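

Chloro in place of carboxy at this place on the ring, ortho to a large group, gives an at least 310-fold lower number from compound 3 to compound 4 (2.49 log units; beyond the scatter) in this assay, so the group held here matters greatly. Among these compounds, the only earlier step, a 1.1-fold lower number from compound 1 to compound 2 (0.04 log units; within the scatter), exchanged two groups on the outer ring, neither of them an acid, and gave no sign of such sensitivity. Compound 3 stands at a limit, so the full size of the new step cannot be read: the limit of > 600 nM in this assay, at which 1 of the 4 values shown sits.

Hydrogen, fluoro or an amine at this place are not among the compounds shown. Going by these compounds, it therefore stays open whether the change owes more to losing carboxy or to gaining chloro.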